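Methyl in place of hydrogen on compound 1

The compounds below may be only part of what the source reports. "The series", "measured", "known", "first", "only" and "open" are said of these compounds alone.

Within the data shown here, in a functional assay on HeLa cells (Homo sapiens) for inhibition, read by CCK-8 assay, with a stated time of 48 h (a higher number here means a weaker inhibitor, a lower number a stronger inhibitor), compound 1 `Cc1ccc(C2=NN(C3=NC(=O)CS3)C(c3ccc4ccccc4c3)C2)cc1` gives 1760 nM and holds the lower of the two numbers so far. Compound 2 `Cc1ccc(C2=NN(C3=NC(c4ccccc4)CS3)C(c3cccc4ccccc34)C2)cc1` gives 4290 nM and stands higher, beyond the scatter. Among the measured compounds shown here, no measured pair differs in one place only. Compound 3 `Cc1ccc(C2=NN(C3=NC(=O)CS3)C(c3ccc4ccccc4c3)C2)cc1C` carries methyl in place of hydrogen on an aromatic carbon and so goes from 4-methylphenyl to 3,4-dimethylphenyl. In this assay no step beyond the scatter is expected, and no direction can be favoured. The estimated move is a 1.1-fold lower number from compound 1 to compound 3 (0.04 log units; within the scatter) and stays within the scatter. Compound 3 is expected at 1600 nM with an estimated range of 700 nM to 3700 nM for this measurement.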

Compound 3, half-maximal inhibitory concentration: 860 nM
Compound 3: the middle estimate sits 1.9-fold (0.27 log units) above what was measured, and the stated range covers the measured number.
By their numbers in this assay, from the lowest: compound 3; then compound 1; then compound 2.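

In this assay, among these compounds, going from 4-methylphenyl to 3,4-dimethylphenyl gives a 2.0-fold lower number from compound 1 to compound 3 (0.31 log units; beyond the scatter) as a modest step, the first comparison that differs in one place only. It shows that a methyl group is accepted on this aromatic carbon, ortho to a methyl group, and that the number moves down rather than up. Nothing available explains the step. The compounds shown leave open whether a methoxy group, a chlorine atom or an amine would act the same way at this position, and whether a longer chain such as ethyl would keep the lower number.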